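Flipping the Drawn Double Bond in Compound 2

This account rests on a few compounds, and the source may have more. Where it says the series, first, only, none or still open, it means among the compounds named here.

Of the compounds shown here, two have been measured in a functional assay on T47D cells (Homo sapiens) for inhibition, read by sulforhodamine B assay, with a stated time of 48 h; a lower number here means a stronger inhibitor of growth, a higher number a weaker inhibitor of growth. Compound 1 `CC(=O)OC/C(=C\c1ccc(Cl)cc1Cl)C(=O)c1ccccc1` gives 9500 nM. Compound 2 `CC(=O)OC/C(=C\c1ccc(Cl)cc1Cl)C(=O)c1ccc(Cl)cc1` gives 5200 nM; of the two numbers it stands alongside compound 1, separated by a 1.8-fold lower number from compound 1 to compound 2 (0.26 log units; within the scatter), a chloro in place of hydrogen on an aromatic carbon, a gap within the scatter. Compound 3 `CC(=O)OC/C(=C/c1ccc(Cl)cc1Cl)C(=O)c1ccc(Cl)cc1` has the same atoms and bonds as compound 2: the two compounds have the same atoms and bonds and differ only in configuration as drawn: 1 of 1 stereo elements differ; a double bond is drawn E in compound 2 and Z in compound 3. Going by the values given here, no measured step concerns a change of drawn configuration; the one step available swaps a group on an aromatic carbon and says nothing about how the two geometries compare in this assay. The expectation therefore rests on compound 2 alone, with a wide range allowed in both directions. Compound 3 is estimated at 6000 nM, between 1500 nM and 25000 nM. That estimate means an expected step of a 1.2-fold higher number from compound 2 to compound 3 (0.06 log units; within the scatter).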

Compound 3, concentration for 50% growth inhibition: 20000 nM
For compound 3 the middle estimate is 3.3-fold (0.52 log units) below the measured one; low and high end bracket the measured number.
By their numbers in this assay, from the lowest: compounds 2 and 1 (each within the scatter of the next); then compound 3.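

In this assay, reversing the drawn geometry of the double bond from E to Z gives a 3.8-fold higher number from compound 2 to compound 3 (0.59 log units; beyond the scatter). Going by these compounds alone, this is the first change that exceeds the scatter, as the earlier swap of hydrogen for chloro on an aromatic carbon stayed within it, and it shows that this double bond's geometry can matter even with no atom added or removed. Within this single pair, the E form is the stronger inhibitor of growth, and the gap can be tied to geometry alone because of one structural point: the fact that compounds 2 and 3 differ only in the configuration as drawn

Within the data shown here, with only one such pair, it remains open whether the same gap would appear with hydrogen in place of that chloro, as in compound 1. Also open, on these data alone, is how either geometry would behave if an amine or a carboxylic acid replaced the acetoxy group.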